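This account rests on a few compounds, and the source may have more. Where it says the series, first, only, none or still open, it means among the compounds named here.

Compound 2 `Cc1cccc(S(=O)(=O)NCc2ccc(CNC(=O)c3ccccc3C)cc2)c1` shows the highest number of the two measured in an assay on MDA-MB-231 cells for displacement of a labelled ligand from C-X-C chemokine receptor type 4 (Homo sapiens), read by fluorescence and microscopy, with stated times of 10 min and 30 min (a lower number here means that less compound is needed, a higher number that more compound is needed for the effect), compound 2 giving 1000 nM. Its nearest neighbour is compound 1 `Cc1ccccc1C(=O)NCc1ccc(CNS(=O)(=O)c2ccc([N+](=O)[O-])cc2)cc1`, which in this assay gives 100 nM; the step of a 10-fold higher number from compound 1 to compound 2 (1.00 log units; beyond the scatter) is the only one measured so far. Compound 3 `Cc1ccccc1C(=O)NCc1ccc(CNS(=O)(=O)c2cccc(Cl)c2)cc1` differs from compound 2 by chloro in place of methyl on an aromatic carbon. Among the compounds with values here, no measured step covers this exchange directly, since the step from compound 1 to compound 2 swaps a different group on the sulfonyl sulfur; it shows only that the ring on that sulfur moves the number. A step of modest size is therefore expected for compound 3, slightly toward a lower number, a 2.0-fold lower number from compound 2 to compound 3 (0.30 log units; within the scatter). Compound 3 is estimated at 500 nM, with a range from 150 nM to 2000 nM.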

Compound 3, effective concentration (reported as EC, without a stated level of effect): 100 nM
Compound 3: the middle estimate sits 5.0-fold (0.70 log units) above what was measured; measured number below the stated range.
By their numbers in this assay, from the lowest: compounds 1 and 3 (each within the scatter of the next); then compound 2.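

Swapping one atom at this position, on an aromatic carbon meta to a large group, is enough to move the number in this assay: chloro in place of methyl gives a 10-fold lower number from compound 2 to compound 3 (1.00 log units; beyond the scatter) and returns it to the level of the 4-nitrophenyl compound. Between the 3-chlorophenyl and 4-nitrophenyl rings on the sulfonyl sulfur, the data show no change at the digits printed from compound 1 to compound 3 (within the scatter), so among these three rings only 3-methylphenyl stands apart. No data bear on the reason for either step. Still open, going by these compounds, is how a methoxy group, an amine or a bromo group at this same position would read, and whether an unsubstituted phenyl ring would sit with the 3-chlorophenyl or the 3-methylphenyl compound.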